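The source may hold more compounds than are shown below. What is called first, only, known or untested is meant among the compounds shown, and "the series" means these compounds.

Among the compounds with values here, in an in vitro assay on BTI-TN-5B1-4 cells for inhibition of Amine oxidase [flavin-containing] B (Homo sapiens), read by fluorescence, with a stated time of 15 min (a higher number here means a weaker inhibitor, a lower number a stronger inhibitor), compound 2 `CCOC(=O)c1cc2ccc(N(CC)CC)cc2oc1=O` gives 45500 nM, the highest of the two numbers measured so far; its nearest neighbour is compound 1 `CCN(CC)c1ccc2cc(C(=O)c3ccccc3)c(=O)oc2c1`, which gives 23800 nM in this assay. Within the data shown here, the only measured step, a 1.9-fold higher number from compound 1 to compound 2 (0.28 log units; within the scatter), concerns the group on the carbonyl carbon and lies within the scatter. Compound 3 `CCOC(=O)c1cc2ccc(OCc3ccccc3)cc2oc1=O` differs from compound 2 at a different place: benzyloxy in place of diethylamino on an aromatic carbon. Among the measured compounds shown here, no measured step touches this aromatic carbon, so the comparison of compound 1 with compound 2 gives no guide to the size or direction of the step to compound 3, and the estimate has to stay broad. Compound 3 is expected to give 5000 nM in this assay, with a range from 500 nM to 50000 nM. For the measured compounds named here, the expected step, a 9.1-fold lower number from compound 2 to compound 3 (0.96 log units; beyond the scatter), rests on no measured step of this kind and is held loosely.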

Compound 3, half-maximal inhibitory concentration: 7.01 nM
The estimate for compound 3 lay 710-fold (2.85 log units) above the measured number, outside the stated range (below it).
By their numbers in this assay, from the lowest: compound 3; then compounds 1 and 2 (each within the scatter of the next).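

In this assay the aromatic carbon that carries diethylamino in compound 2 turns out to matter far more than the group on the carbonyl carbon: benzyloxy in place of diethylamino brings a 6500-fold lower number from compound 2 to compound 3 (3.81 log units; beyond the scatter) while the earlier change, a 1.9-fold higher number from compound 1 to compound 2 (0.28 log units; within the scatter) stayed within the scatter. Both groups count one hydrogen-bond acceptor and no donors, whereas only the entering benzyloxy holds a six-membered aromatic ring of carbon only, and this single step cannot separate that ring from the other differences between the two groups. Nothing available bears on why the step is so large.

The compounds shown leave open whether a methoxy or a plain hydroxyl on this aromatic carbon would keep any of the step. They also leave open whether phenyl in place of ethoxy on the carbonyl carbon would matter alongside benzyloxy.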